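Sulfonamide nitrogen: cyclopentyl replaced by methyl

This account rests on a few compounds, and the source may have more. Where it says the series, first, only, none or still open, it means among the compounds named here.

For the measured compounds named here, in an assay for inhibition of serine/threonine-protein kinase PLK2 (Homo sapiens), read by FRET and Z'-LYTE, with a stated time of 1 h (a lower number here means a stronger inhibitor, a higher number a weaker inhibitor), compound 2 `CC[C@@H]1C(=O)N(C)c2cnc(Nc3ccc(S(=O)(=O)NC4CCCC4)cc3)nc2N1C1CCCC1` gives 23.9 nM, the lowest number among the three measured members. Compound 1 `CCC1C(=O)N(C)c2cnc(-n3ccc4cc(C(N)=O)ccc43)nc2N1c1ccn(C)n1` gives 384 nM in this assay, and compound 3 `CCC1C(=O)N(C)c2cnc(-n3ccc4cc(F)ccc43)nc2N1c1ccn(C)n1` gives 1500 nM; both lie beyond the scatter from compound 2, with compound 1 the nearer of the two. Going by the values given here, the only one-place step measured so far, a 3.9-fold higher number from compound 1 to compound 3 (0.59 log units; beyond the scatter), concerns an aromatic carbon on the shared core of compounds 1 and 3 and does not involve the sulfonamide.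

Compound 4 `CC[C@@H]1C(=O)N(C)c2cnc(Nc3ccc(S(=O)(=O)NC)cc3)nc2N1C1CCCC1` differs from compound 2 in one place: methyl in place of cyclopentyl on a sulfonamide nitrogen. Among the compounds with values here, no measured pair shows what a change on the sulfonamide nitrogen does, so the expectation rests on compound 2 alone, with the single measured step as the only guide to the size a one-group change has produced. A five-heavy-atom group leaves and a one-heavy-atom group enters, which is taken to read as a modest move toward a higher number rather than none. The estimate therefore means a 3.3-fold higher number from compound 2 to compound 4 (0.52 log units; beyond the scatter), a weakening that stays within the same order. Compound 4 is expected to give 80 nM in this assay, between 25 nM and 300 nM.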

Compound 4, half-maximal inhibitory concentration: 3.4 nM
Estimate against measurement, compound 4: 24-fold (1.37 log units) above; the measured number lies below the stated range.
By their numbers in this assay, from the lowest: compound 4; then compound 2; then compound 1; then compound 3.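

In this assay, for the compounds shown here, this is the first measured change on the sulfonamide nitrogen, and it shows that the cyclopentyl ring is not required for a low number here: a 7.0-fold lower number from compound 2 to compound 4 (0.85 log units; beyond the scatter). Removing the ring and leaving a single methyl carbon lowers the number, so at this position fewer heavy atoms go with a lower number in this one pair, and a single pair sets no trend. Nothing available explains the drop, so it stands as an observation on compounds 2 and 4 only.

As far as these compounds go, two substituents on this nitrogen cannot show how the number depends on the group there, and it remains open whether hydrogen, ethyl, isopropyl, a longer chain or a chain ending in an amine or a carboxylic acid would give a lower or a higher number than methyl. From the compounds shown here alone, it is also open whether the same exchange of cyclopentyl for methyl gives a step of similar direction and size on a core other than that of compound 2.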